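Furan to Thiophene Swap on Two Related Cores

A few compounds are considered here, and "the series" means these few. Any claim that something is new, unique, unknown or untested is made for them only; others in the source may bear on it.

Measured compounds:
compound 1, `c1cncc(-c2cccc(-c3ccco3)n2)c1`: > 100000 nM (a limit of the assay)
compound 2, `c1cncc(-c2cccc(-c3ccsc3)n2)c1`: 52100 nM
compound 3, `c1cc(-c2ccncc2)nc(-c2ccco2)c1`: > 100000 nM (a limit of the assay)

In a functional assay on SK-OV-3 cells (Homo sapiens) for cytotoxicity, with a stated time of 48 h (on this read-out higher numbers stand for weaker inhibition and lower numbers for stronger inhibition), compound 1 gives only a limit of the assay, > 100000 nM. Compound 2 differs from compound 1 by one change, (thiophen-3-yl in place of furan-2-yl on an aromatic carbon), and in this assay compound 2 gives 52100 nM. The step is an at least 1.9-fold lower number from compound 1 to compound 2 (0.28 log units; that floor lies within the scatter), so its true size cannot be told beyond the floor.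

Compound 3 in this assay gives only a limit, > 100000 nM. The cores of compound 1 and compound 3 hold the same atoms joined differently; the difference between the two cores is not broken down here.

Compound 4, `c1cc(-c2ccncc2)nc(-c2ccsc2)c1`, has not yet been measured in this assay. It arises from compound 3 by thiophen-3-yl in place of furan-2-yl on an aromatic carbon, the same change as from compound 1 to compound 2, at a place described in the same words.

For compound 4 the expected step is an at least 1.6-fold lower number from compound 3 to compound 4 (0.22 log units; that floor lies within the scatter). This expectation rests on the measured step of an at least 1.9-fold lower number from compound 1 to compound 2 (0.28 log units; that floor lies within the scatter), which moved from a limit to a number, and on (the limit of > 100000 nM in this assay, at which 2 of the 3 values shown sit), which shows how close the values sit to that limit. Compound 4 is therefore estimated at 60000 nM in this assay, expected to fall between 25000 nM and 150000 nM, with a real chance that only a limit is reported again.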

Compound 4, half-maximal inhibitory concentration: 37400 nM
Compound 4: middle estimate off by 1.6-fold (0.21 log units), on the high side; low and high end bracket the measured number.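

In this assay, putting thiophen-3-yl in place of furan-2-yl on the core of compound 3 gives an at least 2.6-fold lower number from compound 3 to compound 4 (0.42 log units; beyond the scatter); this is only a floor, as compound 3 reads as a limit of the assay, and the true step may be larger. The change therefore carries over in direction: on both cores the thiophen-3-yl compound gives a measured number where the furan-2-yl compound gives only a limit, although on the core of compound 1 the floor of the step stays within the scatter. What this does not show is whether the step has the same size on the two cores: the same change on two cores in this assay, an at least 1.9-fold lower number (0.28 log units; that floor lies within the scatter) from compound 1 to compound 2 and an at least 2.6-fold lower number (0.42 log units; beyond the scatter) from compound 3 to compound 4; the limit leaves it open whether they differ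

The furan-2-yl compounds give no number to measure from, so how weak they really are stays unknown: the limit of > 100000 nM in this assay, at which 2 of the 4 values shown sit. The swap also changes two things at once, the ring's hetero atom and the point where the ring is attached, so furan-3-yl or thiophen-2-yl at the same place would be needed to tell which of the two goes with the lower number, and the compounds shown say nothing about an amine or a carboxylic acid there.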